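The source may hold more compounds than are shown below. What is called first, only, known or untested is meant among the compounds shown, and "the series" means these compounds.

In a functional assay on SK-OV-3 cells (Homo sapiens) for antiproliferative activity, read by MTT assay, with a stated time of 24 h (on this read-out lower numbers stand for stronger inhibition and higher numbers for weaker inhibition), compound 1 `COc1ccc(C(=O)/C=C/c2ccsc2)c2c1C=CC(C)(C)O2` gives only a limit of the assay, > 10000 nM. Compound 2 `COc1ccc(C(=O)/C=C/c2ccco2)c2c1C=CC(C)(C)O2` likewise gives only a limit of the assay in this assay, > 10000 nM. Going by the values given here, the single step between measured compounds, a step that the two limits leave unreadable from compound 1 to compound 2, is therefore not readable in size or direction, and compound 2 stands with no number of its own on the scale, only a limit, with the limit of > 10000 nM in this assay, at which 2 of the 2 values shown sit, as the whole of what the measured values show.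

Compound 3 `COc1ccc(C(=O)/C=C/c2ccccn2)c2c1C=CC(C)(C)O2` differs from compound 2 by pyridin-2-yl in place of furan-2-yl on a double-bonded chain carbon bound to a double-bonded chain carbon. Among the compounds with values here, no measured step bears on this change, and the one step is itself unreadable, so no size or direction of step can be drawn from the data for this assay. The expectation for compound 3 therefore rests on both measured values sitting at the limit: compound 3 is estimated at 15000 nM, range 4000 nM to 60000 nM, a step that the limit leaves unreadable from compound 2 to compound 3, most likely again reported as a limit.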

Compound 3, half-maximal inhibitory concentration: 8390 nM
For compound 3 the middle estimate is 1.8-fold (0.25 log units) above the measured one; the measured number falls inside the stated range.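

In this assay compound 3 alone gives a number rather than a limit, so pyridin-2-yl on a double-bonded chain carbon bound to a double-bonded chain carbon brings the series onto the scale, where furan-2-yl and thiophen-3-yl gave no number. The change reads as an at least 1.1-fold lower number from compound 2 to compound 3 (0.07 log units; that floor lies within the scatter), and against the thiophen-3-yl compound as an at least 1.1-fold lower number from compound 1 to compound 3 (0.07 log units; that floor lies within the scatter), so both are floors only and neither establishes a real difference. The overall picture holds: the limit of > 10000 nM in this assay, at which 2 of the 3 values shown sit.

From the compounds shown here alone, the step from compound 1 to compound 2 cannot be read, and the true size of both new steps stays unknown. Going by these compounds, whether the number depends on the ring nitrogen and where it sits remains open; phenyl, pyridin-3-yl or pyridin-4-yl in the same place would bear on that.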